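Swapping an amide for a urea on a shared core

The compounds below may be only part of what the source reports. "The series", "measured", "known", "first", "only" and "open" are said of these compounds alone.

Of the compounds shown here, three of one series have been tested in a functional assay on OVCAR-4 cells (Homo sapiens) for inhibition, read by sulforhodamine B assay, with a stated time of 48 h; a lower number here means that less compound is tolerated, a higher number that more compound is tolerated. Compound 1 `O=C(Nc1cccc(-n2cc(-c3ccncc3)c(-c3ccc(Cl)c(O)c3)n2)c1)Nc1cccc(C(F)(F)F)c1` carries a diaryl urea. In this assay compound 1 reached only the limit of the measurement, > 32500 nM. Compound 2 `COc1cc(-c2nn(-c3cccc(NC(=O)Nc4cc(C(F)(F)F)cc(C(F)(F)F)c4)c3)cc2-c2ccncc2)ccc1Cl` is also a urea, with two trifluoromethyl groups on its outer ring. Compound 2 likewise gave only a limit, > 50000 nM. Compound 3 `COc1cc(-c2nn(-c3cccc(NC(=O)c4cccc(C(F)(F)F)c4)c3)cc2-c2ccncc2)ccc1Cl` differs in that the outer ring is joined directly to the carbonyl, so it is an amide rather than a urea. For compound 3 this assay again reported only a limit, > 50000 nM. Compound 3 therefore stands where every measured value stands: at a limit, with no number to compare, as the limit of > 32500 nM in this assay, at which 1 of the 3 values shown sits, and the limit of > 50000 nM in this assay, at which 2 of the 3 values shown sit, summarise.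

Compound 4 `COc1cc(-c2nn(-c3cccc(NC(=O)Nc4ccc(Cl)c(Cl)c4)c3)cc2-c2ccncc2)ccc1Cl` has not been measured. It differs from compound 3 in one place: (3,4-dichlorophenyl)amino in place of 3-(trifluoromethyl)phenyl on a carbonyl carbon, in words (3,4-dichlorophenyl)amino in place of 3-(trifluoromethyl)phenyl on a carbonyl carbon, so the amide becomes a urea like those of compound 1 and compound 2. Among the compounds with values here, no measured step joins two real numbers here, since every reading is a limit, so no direction can be read from the data. The expected step in this assay is a number no higher from compound 3 to compound 4 (the limit leaves the size open), that is, nothing beyond the scatter. Compound 4 is estimated at 50000 nM, within 15000 nM to 150000 nM, most likely again a limit.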

Compound 4, concentration lethal to 50% of the cells: > 50000 nM
Compound 4 was reported as a limit; the forecaster's own chance of this, stated with the estimate: 70%; the middle value lies on the limit itself.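

Compound 3 and compound 4 both stop at a limit of the measurement, so the step between them cannot be read, in either size or direction. The compounds shown leave open how an amide and a urea compare in this assay, and whether any compound on this shared core gives a real number there rather than a limit.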